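The source may report more compounds than this note shows. Statements on the series, on what has been measured and on what is new or still open speak of the compounds shown alone.

Measured compounds in a functional assay on K562 cells (Homo sapiens) for inhibition, read by trypan blue exclusion, with a stated time of 72 h; on this read-out higher numbers stand for weaker inhibition and lower numbers for stronger inhibition:
Compound 1, `Cn1c(=O)c(S(=O)(=O)c2ccc(Cl)cc2Cl)cc2cnc(Nc3ccc4[nH]ccc4c3)nc21`, gives 1000 nM.
Compound 2, `Cn1c(=O)c(S(=O)(=O)c2ccc(F)cc2F)cc2cnc(Nc3ccc4[nH]ncc4c3)nc21`, gives 50000 nM.
Compound 3, `Cn1ccc2cc(Nc3ncc4cc(S(=O)(=O)c5ccc(Cl)cc5Cl)c(=O)n(C)c4n3)ccc21`, gives 750 nM.

Compound 1 stands second highest of the three numbers. Within the data shown here, its nearest neighbour is compound 3, and the one recorded single-change step, a 1.3-fold lower number from compound 1 to compound 3 (0.12 log units; within the scatter), lies within the scatter, so no order between compound 1 and compound 3 can be read. Among the measured compounds shown here, the furthest is compound 2, whose number is far higher than that of compound 1; compound 2 differs from compound 1 in two places at once, so no single-change step is available for it and its high number cannot be tied to either change alone.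

Compound 4, `Cn1c(=O)c(S(=O)(=O)c2ccc([N+](=O)[O-])cc2F)cc2cnc(Nc3ccc4[nH]ccc4c3)nc21`, is not yet measured. Compared with compound 1 the change is 2-fluoro-4-nitrophenyl in place of 2,4-dichlorophenyl on a sulfonyl sulfur. For the measured compounds named here, no measured step touches the group on the sulfonyl sulfur in isolation; the only recorded step, a methyl in place of hydrogen on an aromatic nitrogen, concerns a different part and was within the scatter. The data therefore give no direction with confidence, and the range must be wide. Compound 4 is estimated at 3000 nM, with a range from 500 nM to 20000 nM. The expected step of a 3.0-fold higher number from compound 1 to compound 4 (0.48 log units; beyond the scatter) is centred on a modest rise in the number but spans both directions.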

Compound 4, half-maximal inhibitory concentration: 200 nM
The estimate for compound 4 lay 15-fold (1.18 log units) above the measured number; measured number below the stated range.
By their numbers in this assay, from the lowest: compound 4; then compounds 3 and 1 (each within the scatter of the next); then compound 2.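

Among these compounds, on the sulfonyl sulfur, the aryl group is the first place where a single change moves the number beyond the scatter: in this assay, 2-fluoro-4-nitrophenyl in place of 2,4-dichlorophenyl gives a 5.0-fold lower number from compound 1 to compound 4 (0.70 log units; beyond the scatter), whereas the earlier single-change step, on the aromatic nitrogen, stayed within the scatter. Both substituents on the ring differ at once, and the entering group carries hydrogen-bond acceptors where the leaving group has none, yet this one step cannot divide the shift between the nitro group, the fluorine and the loss of the two chlorines. Nothing in the data on hand accounts for the lower number at this position.

Still open, on these data alone, is how much of the step belongs to the nitro group alone, and whether an amine, a nitrile or a carboxylic acid in its place would give a number on the same side of compound 1. Also open, as far as these compounds go, is whether 2-fluoro-4-nitrophenyl on the sulfonyl sulfur gives a similar step on the core of compound 3 or on the core of compound 2.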